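Trifluoromethoxy in Place of Ethyl on a Sulfonamide Core

A few compounds are considered here, and "the series" means these few. Any claim that something is new, unique, unknown or untested is made for them only; others in the source may bear on it.

Three compounds built on a shared core have been run in an ADME assay on S9 fraction from liver (Mus musculus, strain ICR/CD-1) for metabolic stability, read by LC-MS, using NADPH, with a stated time of 5 min, tested at 2 uM; on this read-out higher numbers stand for a longer-lived compound and lower numbers for a shorter-lived compound. Compound 1 `Cc1cc(C)c(S(=O)(=O)N2CCC(N3CCC(C)CC3)CC2)c(C)c1` gives 0.0833 h in this assay. Compound 2 `CC1CCN(C2CCN(S(=O)(=O)c3cccc4ccccc34)CC2)CC1` reaches only a limit of this assay, < 0.0834 h, which matches (the limit of < 0.0834 h in this assay, at which 1 of the 3 values shown sits). Compound 3 `CCc1cc(Br)ccc1S(=O)(=O)N1CCC(N2CCC(C)CC2)CC1` gives 0.152 h in this assay. Of the two plain numbers shown, the one for compound 3 is the larger, yet compound 1 is its nearest neighbour and the gap between them lies within the usual scatter, so no real difference between the two can be claimed.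

Compound 4 `CC1CCN(C2CCN(S(=O)(=O)c3ccc(Br)cc3OC(F)(F)F)CC2)CC1` has not yet been measured in this assay. It differs from compound 3 in one place: trifluoromethoxy in place of ethyl on an aromatic carbon. Among the compounds with values here, no pair of measured compounds differs by this same change, so the size of the step is open, and nothing among the measured compounds points to a direction. The step is therefore expected to stay within the scatter, and compound 4 is estimated at 0.17 h with a range from 0.07 h to 0.45 h. The expected step of a 1.1-fold higher number from compound 3 to compound 4 (0.05 log units; within the scatter) is small. A reading that is again only a limit of this assay cannot be ruled out.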

Compound 4, half-life: 0.0833 h
For compound 4 the middle estimate is 2.0-fold (0.31 log units) above the measured one; low and high end bracket the measured number.
By their numbers in this assay, from the lowest: compounds 1, 4 and 3 (each within the scatter of the next).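

Trifluoromethoxy in place of ethyl now has its first measured step at this position, on an aromatic carbon ortho to a large group and meta to a bromo group: in this assay, the change gives a 1.8-fold lower number from compound 3 to compound 4 (0.26 log units; within the scatter). The reading therefore cannot separate the two compounds, even though the entering group brings oxygen and three fluorine atoms in place of a plain two-carbon group, so this single pair gives no sign that the swap matters for half-life on this core. Compound 2 supplies no number that could be set beside this pair, as its reading is only a limit: the limit of < 0.0834 h in this assay, at which 1 of the 4 values shown sits.

Within the data shown here, with only one pair, it remains open whether this result holds for the same change elsewhere on the shared core, or with another group in place of the bromo group. From the compounds shown here alone, it is also open whether a different group at this position, such as an amine, a carboxylic acid or a longer chain, would move the half-life by more than the usual scatter.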